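Swapping the Amine Ring at the End of the Chain

A few compounds are considered here, and "the series" means these few. Any claim that something is new, unique, unknown or untested is made for them only; others in the source may bear on it.

Compound 1 `COc1cc2c(Nc3ccc(C#N)cc3)ncnc2cc1OCCCN1CCC(O)CC1` and compound 2 `COc1cc2c(Nc3ccc(C#N)cc3)ncnc2cc1OCCCN1CCCCC1CCO` share one core and differ only in the ring at the end of the chain. In a functional assay on DU-145 cells (Homo sapiens) for antiproliferative activity, read by MTT assay, with a stated time of 72 h (on this read-out lower numbers stand for stronger inhibition and higher numbers for weaker inhibition), compound 1 gives 74900 nM. Compound 2 reaches only the limit of this assay, > 100000 nM, so no exact number is known for it. The step of an at least 1.3-fold higher number from compound 1 to compound 2 (0.12 log units; that floor lies within the scatter) is thus only a floor, as the limit of > 100000 nM in this assay, at which 1 of the 2 values shown sits, shows. Compound 3 `COc1cc2c(Nc3ccc(C#N)cc3)ncnc2cc1OCCCN1CCc2ccccc2C1` differs from compound 2 by 1,2,3,4-tetrahydroisoquinolin-2-yl in place of 2-(2-hydroxyethyl)piperidin-1-yl on a saturated chain carbon, three bonds along the chain from an oxygen on an aromatic ring. Among the compounds with values here, no measured step covers this change, and the one measured step sits within the scatter. Compound 3 is therefore expected to remain weak, at an estimated 70000 nM (range 20000 nM to 200000 nM). That estimate means a step of an at least 1.4-fold lower number from compound 2 to compound 3 (0.15 log units; that floor lies within the scatter).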

Compound 3, half-maximal inhibitory concentration: > 100000 nM
Compound 3: a limit, no number (the forecaster's own chance of this, stated with the estimate: 50%); at least 1.4-fold (0.15 log units) between middle value and limit.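

Compound 3 also stops at a limit, not a number, as compound 2 does: the limit of > 100000 nM in this assay, at which 2 of the 3 values shown sit. The two limits leave the step between compound 2 and compound 3 unreadable. Putting 1,2,3,4-tetrahydroisoquinolin-2-yl on the chain in place of 4-hydroxypiperidin-1-yl gives an at least 1.3-fold higher number from compound 1 to compound 3 (0.12 log units; that floor lies within the scatter), so this ring, with its carbon-only aromatic ring and no hydrogen-bond donor, brings no clear gain in this assay. On these data alone, whether a morpholin-4-yl ring or a dimethylamino group at this place, or a longer chain, would give a clearly lower number stays open.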